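The compounds below may be only part of what the source reports. "The series", "measured", "known", "first", "only" and "open" are said of these compounds alone.

Values in a functional assay on A549 cells (Homo sapiens) for inhibition, read by MTT assay, with a stated time of 48 h (on this read-out lower numbers stand for stronger inhibition and higher numbers for weaker inhibition), so far:
- Compound 1 `COc1ccc2c(=O)c(/C=C/C(=O)Nc3cccc(C)c3)coc2c1` gives > 100000 nM (a limit, not a number).
- Compound 2 `O=C(/C=C/c1coc2cc(O)ccc2c1=O)NCc1ccccc1` gives > 100000 nM (a limit, not a number).
- Compound 3 `COc1ccc2c(=O)c(/C=C/C(=O)NCc3ccccc3F)coc2c1` gives > 100000 nM (a limit, not a number).

Compound 2 has no number in this assay, only the limit > 100000 nM. Its true place in the series cannot be read, and the other two compounds offer no number to compare it with.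

Compound 4 `Cc1ccc(CNC(=O)/C=C/c2coc3cc(O)ccc3c2=O)cc1` is the next compound to be measured. It differs from compound 2 by methyl in place of hydrogen on an aromatic carbon, which turns benzyl into 4-methylbenzyl (methyl in place of hydrogen on an aromatic carbon).

Within the data shown here, only one measured step bears on this change, and it is a different replacement on an amide-type nitrogen: a step that the two limits leave unreadable from compound 1 to compound 3. It offers no size to carry over. Among the measured compounds shown here, no compound yet shows measurable inhibition, so there is no trend to extend. No step beyond the scatter is expected in either direction because of the limit of > 100000 nM in this assay, at which 3 of the 3 values shown sit.

The expected change in this assay is a number no higher from compound 2 to compound 4 (the limit leaves the size open). Compound 4 will most likely report the same limit, and if it gives a number, that number should lie close to the limit. For compound 4 the estimated value is 100000 nM, with an expected range from 40000 nM to 200000 nM.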

Compound 4, half-maximal inhibitory concentration: 17400 nM
Compound 4: middle estimate off by 5.7-fold (0.76 log units), on the high side; measured number below the stated range.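

In this assay, methyl in place of hydrogen on an aromatic carbon, para to a large group, gives an at least 5.7-fold lower number from compound 2 to compound 4 (0.75 log units; beyond the scatter) and turns benzyl into 4-methylbenzyl. Among these compounds, the earlier step between compounds cannot be read, so this is the first sign that a change on the benzyl group can move the read-out, and a single added methyl is enough to do so. Its full size stays open, since compound 2 has only a limit, and compound 4 is the only compound shown that gives a number, the rest staying at that limit: the limit of > 100000 nM in this assay, at which 3 of the 4 values shown sit.

The compounds shown do not tell whether this step depends on methyl itself or would also appear with a chlorine, a methoxy group or a longer chain such as ethyl at the same place. They also leave open whether 4-methylbenzyl would give a similar step on the methoxy-bearing core of compound 3, where no number is yet available to compare with.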